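Nitrile for methoxy on the pendant bicyclic group

A few compounds are considered here, and "the series" means these few. Any claim that something is new, unique, unknown or untested is made for them only; others in the source may bear on it.

Compound 1 `O=c1[nH]c2ccccc2n1CCCCN1CCN(C(c2ccccc2)c2ccccc2)CC1` gives 180 nM in an assay on RPMI-8226 cells for antagonist activity at P2X purinoceptor 7 (Homo sapiens), read by calcium flux; on this read-out higher numbers stand for weaker inhibition and lower numbers for stronger inhibition. Compound 2 `Cc1ccc2ccn(CCCCN3CCN(C(c4ccccc4)c4ccccc4)CC3)c2c1` gives 6500 nM in this assay. Compound 3 `COc1ccc2c(ccn2CCCCN2CCN(C(c3ccccc3)c3ccccc3)CC2)c1` returns only a limit, > 10000 nM, in this assay, so its true number is not known beyond that bound (the limit of > 10000 nM in this assay, at which 1 of the 3 values shown sits). Compound 3 therefore stands at the weak end of the three, with an at least 55-fold higher number from compound 1 to compound 3 (1.74 log units; beyond the scatter) and a 36-fold higher number from compound 1 to compound 2 (1.56 log units; beyond the scatter) both large, while an at least 1.5-fold higher number from compound 2 to compound 3 (0.18 log units; that floor lies within the scatter) has a floor that is not separated from the scatter.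

Compound 4 `N#Cc1cn(CCCCN2CCN(C(c3ccccc3)c3ccccc3)CC2)c2ccccc12` has not been measured in this assay. The change from compound 3 is a group of 11 heavy atoms (9 carbon, 2 nitrogen; one five-membered aromatic ring with 1 hetero atom, one six-membered aromatic ring of carbon only) in place of a group of 11 heavy atoms (9 carbon, 1 nitrogen, 1 oxygen; one five-membered aromatic ring with 1 hetero atom, one six-membered aromatic ring of carbon only), on a saturated chain carbon, four bonds along the chain from an amine nitrogen in a ring: a nitrile enters on the five-membered aromatic ring and the methoxy group leaves the six-membered ring. Among the compounds with values here, no measured step swaps a nitrile in; the closest comparison is the methyl-to-methoxy exchange, an at least 1.5-fold higher number from compound 2 to compound 3 (0.18 log units; that floor lies within the scatter), which stayed small. Both measured steps onto the bicyclic group of compound 3 show that a single hetero atom in its five-membered ring gives weak numbers in this assay, whatever the substituent on the carbon ring.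

Compound 4 is therefore expected to sit near compound 3, with an at least 1.1-fold lower number from compound 3 to compound 4 (0.04 log units; that floor lies within the scatter) expected to stay within the scatter, and the estimate for compound 4 is 9000 nM, ranging from 2500 nM to 30000 nM.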

Compound 4, half-maximal inhibitory concentration: 1500 nM
For compound 4 the middle estimate is 6.0-fold (0.78 log units) above the measured one; measured number below the stated range.
By their numbers in this assay, from the lowest: compound 1; then compound 4; then compound 2. At a limit, above all of these: compound 3.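

At the place on a saturated chain carbon, four bonds along the chain from an amine nitrogen in a ring, the nitrile-bearing group shows that a single hetero atom in the five-membered aromatic ring does not by itself hold the number at the weak end in this assay, with a 4.3-fold lower number from compound 2 to compound 4 (0.64 log units; beyond the scatter) and an at least 6.6-fold lower number from compound 3 to compound 4 (0.82 log units; beyond the scatter) both beyond the scatter. The second of these steps starts from a limit and not a number, and compound 3 is known only through it: the limit of > 10000 nM in this assay, at which 1 of the 4 values shown sits. The gain is partial, as an 8.3-fold higher number from compound 1 to compound 4 (0.92 log units; beyond the scatter) remains beyond the scatter, so the group with 2 hetero atoms in that ring still gives the lowest number shown.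

The compounds shown do not separate the entry of the nitrile from the loss of the methyl or methoxy group, and they do not tell whether a carboxylic acid, an amide or an amine in the nitrile's stead would behave the same way. From the compounds shown here alone, whether the step holds with a longer chain also stays open.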